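Compound 4: 4-chlorophenyl in place of 3-chlorophenyl

This account rests on a few compounds, and the source may have more. Where it says the series, first, only, none or still open, it means among the compounds named here.

Going by the values given here, in an ADME assay on HeLa cells (Homo sapiens) for cytotoxicity, read by MTT assay (a higher number here means a weaker inhibitor, a lower number a stronger inhibitor), compound 3 (`COc1ccc(C[C@H]2COC(=O)[C@@H]2Cc2ccc(OCc3cn(-c4cccc(Cl)c4)nn3)c(OC)c2)cc1OC`) gives 493000 nM as the highest of three numbers so far. Compound 1 (`COc1ccc(C[C@H]2COC(=O)[C@@H]2Cc2ccc(OCC(=O)Nc3ccc(C)cc3)c(OC)c2)cc1OC`) gives 228000 nM in the same read-out, and compound 2 (`CCN(CC)C(=O)COc1ccc(C[C@H]2C(=O)OC[C@@H]2Cc2ccc(OC)c(OC)c2)cc1OC`) gives 188000 nM there. Exchanging the amine part on the carbonyl carbon gives a 1.2-fold lower number from compound 1 to compound 2 (0.08 log units; within the scatter) and nothing larger.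

Compound 4 (`COc1ccc(C[C@H]2COC(=O)[C@@H]2Cc2ccc(OCc3cn(-c4ccc(Cl)cc4)nn3)c(OC)c2)cc1OC`) has 4-chlorophenyl in place of 3-chlorophenyl on an aromatic nitrogen with the same atoms joined differently. Among the compounds with values here, no measured pair isolates this change. The closest steps replace a whole group on the saturated chain carbon bound to an oxygen on an aromatic ring, giving a 2.2-fold higher number from compound 1 to compound 3 (0.33 log units; beyond the scatter) in one case and a 2.6-fold higher number from compound 2 to compound 3 (0.42 log units; beyond the scatter) in the other, and both are modest. A smaller change than these is expected here, so this assay should show only a 1.1-fold lower number from compound 3 to compound 4 (0.04 log units; within the scatter) as the expected step, with nothing beyond the scatter. For compound 4 the estimated value is 450000 nM with an expected range from 230000 nM to 850000 nM in this read-out.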

Compound 4, half-maximal inhibitory concentration: 279000 nM
Compound 4: the middle estimate sits 1.6-fold (0.21 log units) above what was measured; the range from low to high includes it.
By their numbers in this assay, from the lowest: compounds 2, 1, 4 and 3 (each within the scatter of the next, the first and the last beyond it).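

In this assay the exchange of 3-chlorophenyl for 4-chlorophenyl on the aromatic nitrogen gives a 1.8-fold lower number from compound 3 to compound 4 (0.25 log units; within the scatter) and so does not separate the two isomers at this position. With 1-(4-chlorophenyl)-1H-1,2,3-triazol-4-yl on the saturated chain carbon, both a 1.5-fold higher number from compound 2 to compound 4 (0.17 log units; within the scatter) and a 1.2-fold higher number from compound 1 to compound 4 (0.09 log units; within the scatter) stay within the scatter, whereas compound 3 stood beyond it from compound 1 and from compound 2. No measurement shown bears on the origin of these numbers.

Open, on these data alone, is whether an unsubstituted phenyl or a 4-methoxyphenyl on the same nitrogen would stand apart from compound 3 or compound 4. Also open, as far as these compounds go, is whether a carboxylic acid on the saturated chain carbon would move the number in this assay beyond the scatter of compound 1.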